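Trading a Fluoro for Hydrogen on the Benzyl Ring

This account rests on a few compounds, and the source may have more. Where it says the series, first, only, none or still open, it means among the compounds named here.

Of the compounds shown here, three sharing one core have been tested in an ADME assay on MT4 cells (Homo sapiens) for cytotoxicity, read by MTT assay; on this read-out lower numbers stand for higher toxicity in this test and higher numbers for lower toxicity in this test. Compound 1 `COc1cccc2c1c(C(=O)/C=C(\O)C(=O)O)cn2Cc1c(F)cccc1F` gives 44300 nM, compound 2 `CCOC(=O)/C(O)=C/C(=O)c1cn(Cc2cc(F)c(F)c(F)c2)c2cccc(OC)c12` gives 33400 nM, and compound 3 `COc1cccc2c1c(C(=O)/C=C(\O)C(=O)O)cn2Cc1cc(F)c(F)c(F)c1` gives 23300 nM. Compound 2 holds the second highest of the three numbers; its nearest neighbour is compound 1 and its furthest is compound 3, yet every step among them lies within the scatter, so none of the three can be set apart from the others in this assay.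

The next compound, compound 4 `CCOC(=O)/C(O)=C/C(=O)c1cn(Cc2cc(F)cc(F)c2)c2cccc(OC)c12`, is reached from compound 2 by a single change: hydrogen in place of fluoro on an aromatic carbon. Cut one bond further out, the change reads 3,4,5-trifluorophenyl to 3,5-difluorophenyl.

Going by the values given here, two measured steps bear on this. The step of a 1.9-fold lower number from compound 1 to compound 3 (0.28 log units; within the scatter) swapped the whole fluorine pattern of the benzyl ring and still stayed within the scatter, and the step of a 1.4-fold lower number from compound 2 to compound 3 (0.16 log units; within the scatter) was likewise within the scatter. Removing one fluoro from a ring whose full replacement moved nothing is therefore expected to move nothing beyond the scatter. The expected change is a 1.0-fold lower number from compound 2 to compound 4 (0.01 log units; within the scatter). Compound 4 is accordingly estimated at 33000 nM in this assay, with a range from 15000 nM to 75000 nM.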

Compound 4, half-maximal cytotoxic concentration: 34700 nM
Beside the measured number, compound 4's estimate is 1.1-fold (0.02 log units) below it; low and high end bracket the measured number.
By their numbers in this assay, from the lowest: compounds 3, 2, 4 and 1 (each within the scatter of the next).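

The earlier steps shown here changed the whole fluorine pattern of the benzyl ring or the ethyl group on the oxygen, whereas this one tests a single ring position, the aromatic carbon ortho to two fluoro groups and para to a large group. In this assay, hydrogen in place of fluoro there gives a 1.0-fold higher number from compound 2 to compound 4 (0.02 log units; within the scatter), so 3,4,5-trifluorobenzyl and 3,5-difluorobenzyl cannot be told apart in this test, and the fluoro at this position is not required for the number that compound 2 gives. No measurement is at hand that would account for this result.

The compounds shown carry only fluoro or hydrogen at this position, so it remains open whether a methoxy group, an amine or a carboxylic acid there would also leave the number within the scatter. On these data alone, it also remains open whether hydrogen in place of ethyl on the oxygen next to the carbonyl group behaves on the 3,5-difluorobenzyl compound as it does on the 3,4,5-trifluorobenzyl pair.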